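Hydroxy on the phenyl ring of compound 3

The source may hold more compounds than are shown below. What is called first, only, known or untested is meant among the compounds shown, and "the series" means these compounds.

Of the compounds shown here, three on the shared core have been measured in a functional assay on MCF7 cells (Homo sapiens) for inhibition, read by fluorescence, with a stated time of 72 h (a lower number here means a stronger inhibitor of growth, a higher number a weaker inhibitor of growth), so far. Compound 1 (`CC(C)CCn1cnc2c(Nc3ccc(Cl)cc3)nc(N[C@H]3CC[C@H](N)CC3)nc21`) gives 2700 nM and compound 2 (`COc1cc(Nc2nc(N[C@H]3CC[C@H](N)CC3)nc3c2ncn3CCC(C)C)cc(OC)c1`) gives 4500 nM while compound 3 (`CC(C)CCn1cnc2c(Nc3ccccc3)nc(N[C@H]3CC[C@H](N)CC3)nc21`) gives 5400 nM on the same scale. Compound 3 therefore cannot be separated from the other two, since both of its gaps lie within the scatter.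

Compound 4 (`CC(C)CCn1cnc2c(Nc3ccc(O)cc3)nc(N[C@H]3CC[C@H](N)CC3)nc21`) carries hydroxy in place of hydrogen on an aromatic carbon para to a large group. The nearest comparison is hydrogen in place of chloro, which gave a 2.0-fold higher number from compound 1 to compound 3 (0.30 log units; within the scatter) in this series. Phenyl in place of 3,5-dimethoxyphenyl gave a 1.2-fold higher number from compound 2 to compound 3 (0.08 log units; within the scatter) and 3,5-dimethoxyphenyl in place of 4-chlorophenyl gave a 1.7-fold higher number from compound 1 to compound 2 (0.22 log units; within the scatter) on the same group. For the measured compounds named here, no measured compound carries a hydroxy group, so these steps offer only indirect guidance. All three stay within the scatter, so no step beyond the scatter is expected in this assay and neither direction is favoured. The expected change is a 1.2-fold lower number from compound 3 to compound 4 (0.08 log units; within the scatter) and remains a small one. Compound 4 is estimated at 4500 nM with an expected range from 2000 nM to 10000 nM on the same scale.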

Compound 4, concentration for 50% growth inhibition: 3100 nM
For compound 4 the middle estimate is 1.5-fold (0.16 log units) above the measured one; measured number inside the range.
By their numbers in this assay, from the lowest: compounds 1, 4, 2 and 3 (each within the scatter of the next).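

In this assay, hydroxy in place of hydrogen on an aromatic carbon para to a large group gives a result (a 1.7-fold lower number from compound 3 to compound 4 (0.24 log units; within the scatter)) that stays within the scatter, so this position now holds hydrogen, chloro and hydroxy without any of the three being separated from the others. For the compounds shown here, the comparisons with the other two compounds read the same way: the 4-hydroxyphenyl group in place of 3,5-dimethoxyphenyl gives (a 1.5-fold lower number from compound 2 to compound 4 (0.16 log units; within the scatter)) and hydroxy in place of chloro gives (a 1.1-fold higher number from compound 1 to compound 4 (0.06 log units; within the scatter)), so a hydrogen-bond donor on this ring, absent from the earlier compounds, brings no step beyond the scatter, and all four compounds remain one group on this scale. No supporting data accompany this result, so no reason can be attached to it.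

Among the compounds shown, it remains open whether an amine or a carboxylic acid at this same position would give a step beyond the scatter in this assay. Also open is whether methoxy alone at this position would read differently from hydroxy, since the only methoxy groups shown belong to the 3,5-dimethoxyphenyl group of compound 2.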